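Isopropyl for Methyl Made Once More, Against a Limit

The source may hold more compounds than are shown below. What is called first, only, known or untested is meant among the compounds shown, and "the series" means these compounds.

In a functional assay on PC-3 cells (Homo sapiens) for antiproliferative activity, read by sulforhodamine B assay (on this read-out higher numbers stand for weaker inhibition of growth and lower numbers for stronger inhibition of growth), compound 1 `CC1CC(=O)c2s/c(=N/c3ccccc3)oc2C1` gives 2630 nM. Compound 2 `CC(C)C1CC(=O)c2s/c(=N/c3ccccc3)oc2C1` carries the change isopropyl in place of methyl on a saturated ring carbon and in this assay compound 2 gives 2190 nM; the step of a 1.2-fold lower number from compound 1 to compound 2 (0.08 log units; within the scatter) is a small one. Compound 3 `CC1CC(=O)c2s/c(=N/c3c(Cl)cc(Cl)cc3Cl)oc2C1` rests on a different core, and the difference between the two cores is not broken down here. For compound 3 this assay reports no number but only a limit, > 30000 nM. Compound 4 `CC(C)C1CC(=O)c2s/c(=N/c3c(Cl)cc(Cl)cc3Cl)oc2C1` has not yet been measured in this assay; it differs from compound 3 by isopropyl in place of methyl on a saturated ring carbon, the same change as that made from compound 1 to compound 2, at a place described in the same words. Since that earlier step stayed within the scatter, the step that the limit leaves unreadable from compound 3 to compound 4 is expected to be small as well. Because compound 3 sits at the limit of > 30000 nM in this assay, at which 1 of the 3 values shown sits, compound 4 is also expected to remain there. Compound 4 is therefore estimated to give 40000 nM in this assay, likely again as a limit, with a range from 15000 nM to 150000 nM.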

Compound 4, concentration for 50% growth inhibition: > 30000 nM
Compound 4: a limit, no number; the forecaster's own chance of this, stated with the estimate: 75%; the middle value does not contradict the limit.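

In this assay compound 3 and compound 4 are both reported only as limits and not as numbers, so no step between them can be read: the limit of > 30000 nM in this assay, at which 2 of the 4 values shown sit.

The compounds shown leave open what isopropyl in place of methyl on a saturated ring carbon does to growth inhibition on the core of compound 3.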